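One Flipped Ring Centre, Starting From a Limit

A few compounds are considered here, and "the series" means these few. Any claim that something is new, unique, unknown or untested is made for them only; others in the source may bear on it.

Of the compounds shown here, two have been tested in a functional assay on SNB-75 cells (Homo sapiens) for inhibition; on this read-out higher numbers stand for weaker inhibition of growth and lower numbers for stronger inhibition of growth. Compound 1 `CC1=C(CC/C(C)=C/CC[C@@]2(C)CC[C@@H]([C@H](C)C(=O)O)OO2)C(C)(C)CCC1` gives only a limit in this assay, > 100000 nM, so no number is known for it; it sits at the limit (the limit of > 100000 nM in this assay, at which 1 of the 2 values shown sits). Compound 2 `C=C1CCC[C@H]2[C@](C)(CC[C@]3(C)CC[C@H]([C@@H](C)C(=O)O)OO3)[C@@H](C)CC[C@]12C` gives 1080 nM in this assay. Compound 3 `CC1=C(CC/C(C)=C/CC[C@@]2(C)CC[C@H]([C@H](C)C(=O)O)OO2)C(C)(C)CCC1` is not yet measured. the two compounds have the same atoms and bonds and differ only in configuration as drawn: 1 of 4 stereo elements differ; a stereocentre at a saturated ring carbon is drawn S in compound 1 and R in compound 3 Because compound 1 rests at the limit of > 100000 nM in this assay, at which 1 of the 2 values shown sits, only a move toward stronger inhibition, or none, could become visible. The expected step of an at least 2.0-fold lower number from compound 1 to compound 3 (0.30 log units; that floor lies within the scatter) is modest, with a fair chance of another limit. Compound 3 is estimated at 50000 nM, within 5000 nM to 100000 nM.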

Compound 3, concentration for 50% growth inhibition: > 5000 nM
Compound 3 gave a limit, no number; the forecaster's own chance of this, stated with the estimate: 50%; the middle value does not contradict the limit.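

Compound 1 and compound 3 both give limits rather than numbers, so the step between them cannot be read. On these data alone, whether the one stereocentre drawn S in compound 1 and R in compound 3 changes growth inhibition remains open.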